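This account rests on a few compounds, and the source may have more. Where it says the series, first, only, none or still open, it means among the compounds named here.

Measured so far:
compound 1, `COc1cc(/C=C/C(=O)c2cccc(NC(=O)c3cccs3)c2)ccc1O`: 90%
compound 2, `COc1cc(/C=C/C(=O)c2cccc(NC(=O)c3cc(Cl)cc(Cl)c3)c2)ccc1O`: 58%
compound 3, `COc1cc(/C=C/C(=O)c2cccc(NC(=O)c3ccc(Cl)cc3Cl)c2)ccc1O`: 70%

In a functional assay on HUVEC cells (Homo sapiens) for inhibition, tested at 10 ug/mL (on this read-out lower numbers stand for a weaker effect and higher numbers for a stronger effect at the one concentration tested), compound 1 stands highest of the three, with compound 3 nearest and compound 2 furthest. Compound 4, `CCOC(=O)C(=O)Nc1cccc(C(=O)/C=C/c2ccc(O)c(OC)c2)c1`, is not yet measured; it differs from compound 1 in one place: ethoxycarbonyl in place of thiophen-2-yl on a carbonyl carbon. Within the data shown here, two measured steps bear on this, since each also exchanges the thiophen-2-yl on that carbonyl carbon: a number 32 percentage points lower from compound 1 to compound 2 (beyond the scatter) and a number 20 percentage points lower from compound 1 to compound 3 (beyond the scatter). Both point downward, one large and one modest. A similar drop is therefore expected for compound 4, here with a group carrying no ring entering. For compound 4 the estimated result in this assay is 62%, within 35% to 85%. The expected step is a number 28 percentage points lower from compound 1 to compound 4 (beyond the scatter).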

Compound 4, a percentage reported as inhibition, at one concentration (the size of the read-out at that concentration, not a potency): 66%
The estimate for compound 4 lay 4 percentage points below the measured number; measured number inside the range.
By their numbers in this assay, from the lowest: compounds 2, 4 and 3 (each within the scatter of the next, the first and the last beyond it); then compound 1.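

In this assay the fall away from thiophen-2-yl does not depend on a replacement carrying a ring: ethoxycarbonyl, which has no ring, gives a number 24 percentage points lower from compound 1 to compound 4 (beyond the scatter) on this carbonyl carbon. This group also cannot be told apart from either dichlorophenyl group, with a number 4 percentage points lower from compound 3 to compound 4 (within the scatter) and a number 8 percentage points higher from compound 2 to compound 4 (within the scatter) as the two comparisons. So thiophen-2-yl alone stands out among these groups, though nothing measured here explains why. On these data alone, whether furan-2-yl would match thiophen-2-yl remains open, as does whether a carboxylic acid in place of ethoxycarbonyl would change the result.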